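Phenyl in place of thiophen-3-yl: working notes

The source may hold more compounds than are shown below. What is called first, only, known or untested is meant among the compounds shown, and "the series" means these compounds.

compound 1 `COc1nc(N)nc2c1c(-c1ccoc1)cn2[C@@H]1O[C@H](CO)[C@@H](O)[C@H]1O`: > 100000 nM
compound 2 `COc1nc(N)nc2c1c(-c1cccs1)cn2[C@@H]1O[C@H](CO)[C@@H](O)[C@H]1O`: 99900 nM
compound 3 `COc1nc(N)nc2c1c(-c1ccsc1)cn2[C@@H]1O[C@H](CO)[C@@H](O)[C@H]1O`: > 100000 nM

In an ADME assay on BJ cells (Homo sapiens), read by MTT assay, with a stated time of 72 h (a higher number here means a weaker inhibitor, a lower number a stronger inhibitor), compound 3 gives > 100000 nM, which is a limit and not a number. Compound 1 likewise gives > 100000 nM, also a limit. The series therefore stands largely at the limit of > 100000 nM in this assay, at which 2 of the 3 values shown sit. The next compound is compound 4 `COc1nc(N)nc2c1c(-c1ccccc1)cn2[C@@H]1O[C@H](CO)[C@@H](O)[C@H]1O`, with phenyl in place of thiophen-3-yl on an aromatic carbon.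

The measured steps that bear on this are swaps of the aromatic group at the same place: a number no higher from compound 1 to compound 2 (the limit leaves the size open), a step that the two limits leave unreadable from compound 1 to compound 3 and a number no lower from compound 2 to compound 3 (the limit leaves the size open). Among the compounds with values here, none of them has a readable size, and no phenyl compound has been measured yet. Within the data shown here, compound 2 holds the only numerical reading, at 99900 nM, so no step beyond the scatter is expected in either direction in this assay. The estimated step is a number no higher from compound 3 to compound 4 (the limit leaves the size open). For compound 4 the expected value is 100000 nM, within an estimated range of 40000 nM to 250000 nM.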

Compound 4, half-maximal inhibitory concentration: > 100000 nM
Compound 4: a limit, no number; the forecaster's own chance of this, stated with the estimate: 60%; the middle value sits exactly at the limit.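

At this position on the shared core, the change from a five-membered aromatic ring to a six-membered aromatic ring of carbon only still gives no numerical reading in this assay, so the limit now extends to phenyl as well as furan-3-yl and thiophen-3-yl: the limit of > 100000 nM in this assay, at which 3 of the 4 values shown sit.

Within the data shown here, the one step with a direction is a number no lower from compound 2 to compound 4 (the limit leaves the size open); the other two steps to compound 4 cannot be read.

It remains open whether any group on this aromatic carbon gives a value clearly short of the limit, as the compounds shown carry only aromatic rings there. An amine, a carboxylic acid or a longer alkyl chain in this place has no reading among them, and the size of any difference among the four aromatic groups also remains unresolved.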